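The compounds below may be only part of what the source reports. "The series", "measured", "known", "first", "only" and "open" are said of these compounds alone.

Compound 1, `C[C@]1(O)C[C@@H](OC(=O)/C=C/c2ccccc2)[C@@H]2C=CO[C@@H](O[C@@H]3O[C@H](CO)[C@@H](O)[C@H](O)[C@H]3O)[C@@H]21`, in a functional assay on Bel-7402 cells (Homo sapiens) for cytotoxicity, read by MTT assay, with a stated time of 4 days (on this read-out higher numbers stand for weaker inhibition and lower numbers for stronger inhibition), gives > 10000 nM, which is a limit of the assay rather than a number.
Compound 2, `COc1cc(C(=O)O[C@@H]2C[C@](C)(O)[C@H]3[C@H](O[C@@H]4O[C@H](CO)[C@@H](O)[C@H](O)[C@H]4O)OC=C[C@H]32)cc(OC)c1O[C@@H]1O[C@@H](C)[C@H](O)[C@@H](O)[C@H]1O`, in this assay gives > 10000 nM, again a limit and not a number.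

Compound 1 therefore stands at the edge of what this assay can report: the limit of > 10000 nM in this assay, at which 2 of the 2 values shown sit. Going by the values given here, compound 2 sits at the same edge, so the two values show only that neither compound reached measurable inhibition, and nothing about how far apart the two actually lie.

Compound 3, `C[C@]1(O)C[C@@H](OC(=O)CCc2cc(O)ccn2)[C@@H]2C=CO[C@@H](O[C@@H]3O[C@H](CO)[C@@H](O)[C@H](O)[C@H]3O)[C@@H]21`, has not been measured. It is built on the same core as compound 1 and differs from it in one place: 2-(4-hydroxypyridin-2-yl)ethyl in place of 2-phenylethenyl on a carbonyl carbon. No measured pair differing in exactly this way is available, so the size of this step cannot be read from any shown data.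

Given that compound 1 sits at the limit, the expected step in this assay is a step that the limit leaves unreadable from compound 1 to compound 3, with no clear direction beyond the scatter. For compound 3 the estimate in this assay is 15000 nM, ranging from 4000 nM to 60000 nM, most likely reported again as a limit.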

Compound 3, half-maximal inhibitory concentration: > 10000 nM
Compound 3 gave a limit, no number (the forecaster's own chance of this, stated with the estimate: 80%); the middle value lies beyond the limit too.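

In this assay compound 3 gives > 10000 nM and that is a limit of the assay, not a number. The change from compound 1 to compound 3 therefore has no readable size: the limit of > 10000 nM in this assay, at which 3 of the 3 values shown sit.

From the compounds shown here alone, whether 2-(4-hydroxypyridin-2-yl)ethyl and 2-phenylethenyl differ at all in this read-out, and how compound 1, compound 2 and compound 3 rank, stays open.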